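Propylamino to Azepanyl: Cytotoxicity Expected for Compound 3

The compounds below may be only part of what the source reports. "The series", "measured", "known", "first", "only" and "open" are said of these compounds alone.

Measured compounds:
compound 1, `CCCNc1nc(C(C)c2c(F)cccc2F)c(C)c(=O)[nH]1`, with 35000 nM
compound 2, `CC(c1cc(=O)[nH]c(N(C)C)n1)c1c(F)cccc1F`, with 89000 nM

Of the compounds shown here, two on a shared core have been tested in an ADME assay on MT4 cells (Homo sapiens) for cytotoxicity, read by MTT assay, with a stated time of 4 days; on this read-out higher numbers stand for lower toxicity in this test and lower numbers for higher toxicity in this test. Compound 1 gives 35000 nM in this assay, and compound 2 gives 89000 nM. Compound 1 thus stands at the lower of the two numbers, and the gap to compound 2 is beyond the usual scatter of repeated measurements, so compound 1 is the more toxic of the pair in this test. The two compounds differ in more than one place, so their gap is not tied to a single change.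

Compound 3, `Cc1c(C(C)c2c(F)cccc2F)nc(N2CCCCCC2)[nH]c1=O`, has not yet been measured in this assay. It differs from compound 1 in one place: azepan-1-yl in place of propylamino on an aromatic carbon. For the measured compounds named here, no measured pair shows this kind of change, so there is no step on which to lean. On the two numbers available, a modest move toward higher toxicity is expected, though one that could stay within the scatter. Compound 3 is therefore estimated at 20000 nM, with a range from 7000 nM to 60000 nM. The expected step is a 1.8-fold lower number from compound 1 to compound 3 (0.24 log units; within the scatter).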

Compound 3, half-maximal cytotoxic concentration: > 72000 nM
Compound 3 gave a limit, no number (the forecaster's own chance of this, stated with the estimate: 15%); middle value at least 3.6-fold (0.55 log units) away from the limit.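

Azepan-1-yl in place of propylamino on an aromatic carbon, between two ring nitrogen atoms, gives an at least 2.0-fold higher number from compound 1 to compound 3 (0.31 log units; beyond the scatter) in this assay, and this is the only single-place change shown at this position. It shows that this position can carry a seven-membered non-aromatic ring, with 0 hydrogen-bond donors in the group that enters, and that the step runs toward lower toxicity in this test rather than higher. For compound 3 the read-out is a limit of the assay and not a number: the limit of > 72000 nM in this assay, at which 1 of the 3 values shown sits.

The compounds shown do not separate the ring itself from the loss of the hydrogen-bond donor, and a dipropylamino group, which has no ring and no such donor, or a piperidin-1-yl group, which has a smaller ring, at this position could tell these apart. They also leave open whether azepan-1-yl in place of propylamino gives a step in the same direction on a core that lacks the methyl group.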